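Anilino for 2-fluorophenyl on the thiazole acid

This account rests on a few compounds, and the source may have more. Where it says the series, first, only, none or still open, it means among the compounds named here.

Measured so far:
compound 1, `Fc1ccccc1Nc1nc(-c2ccccn2)cs1`: < 0.0167 h in an ADME assay on microsomes from liver (Mus musculus) for metabolic stability, read by LC-MS, using NADPH; on this read-out lower numbers stand for a shorter-lived compound and higher numbers for a longer-lived compound
compound 2, `COc1ccccc1Nc1nc(-c2ccccn2)cs1`: 0.035 h
compound 3, `O=C(O)c1cccc(-c2csc(-c3ccccc3F)n2)c1`: 3.4 h

The value of compound 1 in this assay is a limit of the assay, not a number (the limit of < 0.0167 h in this assay, at which 1 of the 3 values shown sits). Compound 2 gives a number, and compound 3 gives the highest number of the set, far above compound 2. Going by the values given here, the only single-point step measured so far, an at least 2.0-fold higher number from compound 1 to compound 2 (0.32 log units; beyond the scatter), concerns the group on the anilino ring of the shared core and does not touch the change considered here.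

Compound 4, `O=C(O)c1cccc(-c2csc(Nc3ccccc3)n2)c1`, differs from compound 3 in one place: anilino in place of 2-fluorophenyl on an aromatic carbon. Among the compounds with values here, no measured step bears on this change directly. What the numbers show is that compound 1 and compound 2, both carrying an anilino group on the core, sit at or near the short-lived end of this assay, while compound 3, with 2-fluorophenyl on the core and the benzoic acid, sits at the long-lived end; the two pairs also differ in the second group on the core, so the comparison is not clean.

On that basis compound 4 is expected to give a shorter half-life than compound 3, with the step of an 8.5-fold lower number from compound 3 to compound 4 (0.93 log units; beyond the scatter) estimated as a drop beyond the scatter. The estimate for compound 4 is 0.4 h, within a range from 0.04 h to 3.4 h.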

Compound 4, half-life: 0.802 h
The estimate for compound 4 lay 2.0-fold (0.30 log units) below the measured number; measured number inside the range.
By their numbers in this assay, from the lowest: compound 2; then compound 4; then compound 3. At a limit, below all of these: compound 1.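

In this assay, going by these compounds alone, the single change at the aromatic carbon next to the ring nitrogen and next to the ring sulfur gives a 4.2-fold lower number from compound 3 to compound 4 (0.63 log units; beyond the scatter), and this is the first direct reading of anilino against 2-fluorophenyl with the rest of the molecule held constant. The step is modest but beyond the scatter, and compound 4 still gives a number, 0.802 h, rather than a limit of the assay, so on this carboxylic acid scaffold the anilino group does not bring the half-life down to the bottom of the measured range. The entering anilino carries a hydrogen-bond donor and a hydrogen-bond acceptor where 2-fluorophenyl carries neither, but nothing shown here ties the step to that difference or to any other cause.

Within the data shown here, whether the same change gives a step of similar size with a different second group on the core remains open, since this pair is the only reading of it. Also open, as far as these compounds go, is how the half-life responds to an amide in place of the carboxylic acid, or to a methyl group on the anilino nitrogen.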